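Swapping One Ring Group in a Short-Lived Compound

The compounds below may be only part of what the source reports. "The series", "measured", "known", "first", "only" and "open" are said of these compounds alone.

Compound 1 `C[C@@H](O)[C@H]1C(=O)N2C(C(=O)OCOC(=O)O[C@H]3CCCc4ccccc43)=C(S[C@@H]3CN[C@H](C(=O)N(C)C)C3)[C@H](C)[C@H]12` (0.015 h)
Compound 2 `CC(=O)N1C[C@@H](SC2=C(C(=O)OCOC(=O)O[C@H]3CCCCc4ccccc43)N3C(=O)[C@H]([C@@H](C)O)[C@H]3[C@H]2C)C[C@H]1C(=O)N(C)C` (0.467 h)

These two values come from a physicochemical assay for metabolic stability, read by HPLC, at pH 6, tested at 100 uM (a higher number here means that the compound lasts longer, a lower number that the compound disappears faster), and give a half-life for each compound. Within the data shown here, compound 1 stands lowest at 0.015 h and has only one neighbour to compare with. Compound 2 lies higher, and the gap between the two is beyond the usual scatter of repeated measurements.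

Compound 3 `C[C@@H](O)[C@H]1C(=O)N2C(C(=O)OCOC(=O)O[C@@H]3CCCCc4ccccc43)=C(S[C@@H]3CN[C@H](C(=O)N(C)C)C3)[C@H](C)[C@H]12` differs from compound 1 in a single place (a group of 11 heavy atoms (11 carbon; one six-membered aromatic ring of carbon only, one seven-membered non-aromatic ring of carbon only) in place of a group of 10 heavy atoms (10 carbon; one six-membered non-aromatic ring of carbon only, one six-membered aromatic ring of carbon only), on an oxygen next to a carbonyl group). The 1,2,3,4-tetrahydronaphthalen-1-yl group leaves, and the group that enters carries a seven-membered non-aromatic ring of carbon only instead of the six-membered one. Among the measured compounds shown here, no measured pair shows what this swap does, so any forecast here is a cautious one. It rests on compound 1 at 0.015 h and on the rest of the structure staying the same. With no clear reason to favour either direction, the expected step of a 1.2-fold higher number from compound 1 to compound 3 (0.08 log units; within the scatter) stays within the scatter. The expected half-life of compound 3 is 0.018 h (range 0.007 h to 0.045 h).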

Compound 3, half-life: 0.533 h
Beside the measured number, compound 3's estimate is 30-fold (1.47 log units) below it; measured number outside the range, above it.
By their numbers in this assay, from the lowest: compound 1; then compounds 2 and 3 (each within the scatter of the next).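

In this assay, the oxygen next to a carbonyl group proves to be a place where a modest swap can matter a great deal: replacing the 1,2,3,4-tetrahydronaphthalen-1-yl group with the group carrying a seven-membered non-aromatic ring of carbon only gives a 36-fold higher number from compound 1 to compound 3 (1.55 log units; beyond the scatter). The two groups are alike in several counted features, as each holds a six-membered aromatic ring of carbon only, no hydrogen-bond donors or acceptors, no net charge and one defined stereocentre, while their non-aromatic rings are six-membered in one and seven-membered in the other. Nothing measured here gives a reason for the size of this step.

On these data alone, this step rests on a single pair of compounds, so it remains open whether the same swap would have a similar effect on a different core. Also open, as far as these compounds go, is where a group without a ring, such as a plain ethyl chain, or a group carrying an amine would fall on this half-life scale if placed on the same oxygen.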